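The source may report more compounds than this note shows. Statements on the series, on what has been measured and on what is new or still open speak of the compounds shown alone.

In an in vivo ADME assay on the whole organism (strain C57BL/cAnNCrl) for pharmacokinetics, with Mus musculus as the target, at a dose of 10 mg/kg by the oral route (a lower number here means that a smaller share of the oral dose reaches the circulation, a higher number that a larger share of the oral dose reaches the circulation), compound 3 `Cc1ccc(-n2nc(C(C)(C)C)cc2NC(=O)Nc2ccc(Oc3ccnc4[nH]c(=O)cnc34)cc2)cc1` gives 17%. Of the three compounds measured, compound 1 `CSc1cc(Oc2ccnc3[nH]c(=O)cnc23)ccc1NC(=O)Nc1cc(C(C)(C)C)nn1-c1ccc(C)cc1` gives 71% and compound 2 `Cc1ccc(-n2nc(C(C)(C)C)cc2NC(=O)Nc2ccc(Oc3ccnc4[nH]c(S)nc34)cc2F)cc1` gives 13%, so compound 3 stands second highest, far below compound 1 and within the scatter of compound 2. Among the measured compounds shown here, the only step measured in one place is a number 54 percentage points lower from compound 1 to compound 3 (beyond the scatter). Compound 4 `Cc1ccc(-n2nc(C(C)(C)C)cc2NC(=O)Nc2ccc(Oc3ccnc4[nH]c(=O)cnc34)cc2F)cc1` differs from compound 3 by fluoro in place of hydrogen on an aromatic carbon. For the measured compounds named here, no measured step isolates this change; compound 2 also carries a fluoro but on a different core, and its value sits within the scatter of compound 3. The chemist therefore expects no step beyond the scatter, a number 1 percentage points higher from compound 3 to compound 4 (within the scatter), and estimates compound 4 at 18%, between 8% and 35%.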

Compound 4, oral bioavailability: 24%
Compound 4: middle estimate off by 6 percentage points, on the low side; low and high end bracket the measured number.
By their numbers in this assay, from the lowest: compounds 2, 3 and 4 (each within the scatter of the next, the first and the last beyond it); then compound 1.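

In this assay, fluoro in place of hydrogen on this aromatic carbon gives a number 7 percentage points higher from compound 3 to compound 4 (within the scatter), so the change moves the number no further than the scatter. With fluoro at this place in both, the exchange of the other group gives a number 11 percentage points higher from compound 2 to compound 4 (beyond the scatter), while fluoro in place of methylsulfanyl gives a number 47 percentage points lower from compound 1 to compound 4 (beyond the scatter), so fluoro does not match methylsulfanyl here. Nothing measured bears on the cause of these steps. The compounds shown leave open whether a chloro or a methoxy group on this carbon would stand nearer to compound 1 or to compound 3.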